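Same Atoms, New Arrangement: From Compound 3 to Compound 4

A few compounds are considered here, and "the series" means these few. Any claim that something is new, unique, unknown or untested is made for them only; others in the source may bear on it.

Three related compounds have been measured in an ADME assay on microsomes from liver (Homo sapiens) for metabolic stability, read by LC-MS, with a stated time of 10 min; a higher number here means that more of the compound is left, a lower number that less of the compound is left. Compound 1 `CN(C[C@H]1Cc2c(cccc2N2CCN(C3COC3)CC2)CN1)[C@H]1CCCc2cccnc21` gives 83.1%, compound 2 `CN(C[C@H]1Cc2c(cccc2N2CCNC(C)(C)C2)CN1)[C@H]1CCCc2cccnc21` gives 100%, and compound 3 `CC(C)N1CCN(c2cccc3c2C[C@H](CN(C)[C@H]2CCCc4cccnc42)NC3)CC1` gives 56.6%, the lowest of the three.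

The unmeasured compound 4 `C[C@@H]1CN(c2cccc3c2C[C@H](CN(C)[C@H]2CCCc4cccnc42)NC3)C[C@H](C)N1C` keeps the shared core but carries 3,4,5-trimethylpiperazin-1-yl in place of 4-isopropylpiperazin-1-yl on an aromatic carbon. The two compounds have the same atoms, joined differently.

All three measured steps change this same group. The step of a number 16.9 percentage points higher from compound 1 to compound 2 (beyond the scatter) is modest, as is the step of a number 26.5 percentage points lower from compound 1 to compound 3 (beyond the scatter), while the step of a number 43.4 percentage points lower from compound 2 to compound 3 (beyond the scatter) is large. So each change here moved the number beyond the scatter, although none of the measured compounds carries the new group. Compound 4 does share methyl groups on its piperazine with compound 2, and that link to the large step of a number 43.4 percentage points lower from compound 2 to compound 3 (beyond the scatter) points to an upward move, though only part of the way. The expectation is therefore a modest estimated rise, a number 9.4 percentage points higher from compound 3 to compound 4 (within the scatter). For compound 4 the estimated value in this assay is 66%, with an expected range of 42% to 90%.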

Compound 4, percent of the compound remaining: 24.6%
Beside the measured number, compound 4's estimate is 41.4 percentage points above it; the measured number lies below the stated range.
By their numbers in this assay, from the lowest: compound 4; then compound 3; then compound 1; then compound 2.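

In this assay, the entering group has the same heavy atoms, the same ring and the same counts of hydrogen-bond donors and acceptors as the group it replaces, yet the step is large (a number 32 percentage points lower from compound 3 to compound 4 (beyond the scatter)), so on this aromatic carbon the arrangement of the atoms matters and not only their number. Methyl groups on the piperazine also do not go with a high number in themselves: 3,3-dimethylpiperazin-1-yl and 3,4,5-trimethylpiperazin-1-yl both carry them, yet this exchange gives the largest step in the series (a number 75.4 percentage points lower from compound 2 to compound 4 (beyond the scatter)). The new group also falls well short of 4-(oxetan-3-yl)piperazin-1-yl (a number 58.5 percentage points lower from compound 1 to compound 4 (beyond the scatter)), which makes compound 4 the lowest of the four, with all its steps beyond the scatter.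

No supporting data explain these differences.

The compounds shown leave open how a morpholine at this place would compare, and whether a piperazine with a single methyl group, or the 3,4,5-trimethylpiperazin-1-yl group with its two stereocentres defined the other way, would stay as low as compound 4.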